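This account rests on a few compounds, and the source may have more. Where it says the series, first, only, none or still open, it means among the compounds named here.

Compound 2 `O=C1Nc2ccc(Cl)cc2/C1=N/NC(=S)N1CCN(c2ccccc2F)CC1` is tested in a functional assay on MCF7 cells (Homo sapiens) for inhibition, read by MTT assay, with a stated time of 72 h (a lower number here means a stronger inhibitor, a higher number a weaker inhibitor), where compound 2 gives 15200 nM. Among the two numbers known, this is the highest; its nearest neighbour is compound 1 `O=C1Nc2ccc(Cl)cc2/C1=N/NC(=S)N1CCN(c2ccccc2)CC1`, for which this assay shows 10400 nM. Going by the values given here, the only step recorded, a 1.5-fold higher number from compound 1 to compound 2 (0.16 log units; within the scatter), lies within the scatter of the method.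

Compound 3 `O=C1Nc2ccc(Cl)cc2/C1=N/NC(=S)N1CCN(c2ccc([N+](=O)[O-])cc2)CC1` differs from compound 2 in one place: 4-nitrophenyl in place of 2-fluorophenyl on an amine nitrogen in a ring. Among the compounds with values here, the one measured step bears on this change only in that it also alters a substituent on the same phenyl ring, and it produced no shift beyond the scatter. Within the data shown here, no step from a fluoro-bearing to a nitro-bearing ring has been measured, so the direction of any effect is unknown. In this assay compound 3 is therefore expected to give a number close to compound 2, with the step of a 1.3-fold lower number from compound 2 to compound 3 (0.10 log units; within the scatter) expected to stay within the scatter. Compound 3 is estimated at 12000 nM, in a range from 4000 nM to 36000 nM.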

Compound 3, half-maximal inhibitory concentration: 20900 nM
Beside the measured number, compound 3's estimate is 1.7-fold (0.24 log units) below it; low and high end bracket the measured number.
By their numbers in this assay, from the lowest: compounds 1, 2 and 3 (each within the scatter of the next).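

Going by these compounds alone, compound 3 brings a nitro group onto the phenyl ring on the ring nitrogen, where the earlier compounds carried only hydrogen or fluoro, and in this assay the numbers still do not separate: the exchange of 2-fluorophenyl for 4-nitrophenyl gives a 1.4-fold higher number from compound 2 to compound 3 (0.14 log units; within the scatter) and nitro in place of hydrogen gives a 2.0-fold higher number from compound 1 to compound 3 (0.30 log units; within the scatter) in the same assay. Phenyl, 2-fluorophenyl and 4-nitrophenyl at this position therefore cannot be told apart by this assay as it stands. No measurement available here accounts for this result.

The compounds shown leave open whether moving the fluoro or nitro group elsewhere on the phenyl ring would change the number. They also leave open what an amine or a carboxylic acid on that ring, or a benzyl or methyl group in place of the phenyl ring, would do.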